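Swapping a Ring for a Sulfonamide Chain at the Amide

The compounds below may be only part of what the source reports. "The series", "measured", "known", "first", "only" and "open" are said of these compounds alone.

Of the compounds shown here, three built on one shared core have been measured in an assay on HEK293 cells for displacement of a labelled ligand from NPC1-like intracellular cholesterol transporter 1 (Homo sapiens); on this read-out lower numbers stand for stronger inhibition and higher numbers for weaker inhibition. Compound 2 `CC(C)(C)c1ccc(C(=O)N2CCC3(CC2)C(=O)N(CC(=O)N2CCC(O)CC2)CN3c2ccccc2)cc1` gives 4700 nM. Compound 3 `CC(C)(C)c1ccc(C(=O)N2CCC3(CC2)C(=O)N(CC(=O)N2CCCCC2CO)CN3c2ccccc2)cc1` gives 11800 nM, and compound 1 `CC(C)(C)OC(=O)NCCCCCNC(=O)CN1CN(c2ccccc2)C2(CCN(C(=O)c3ccc(C(C)(C)C)cc3)CC2)C1=O` gives 13700 nM. Compound 3 thus stands second highest of the three: its number lies within the scatter of compound 1, while compound 2 lies clearly lower. Going by the values given here, the only single-point step among them, a 2.5-fold higher number from compound 2 to compound 3 (0.40 log units; beyond the scatter), shows that exchanging the group on the carbonyl carbon can move the number beyond the scatter.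

Compound 4 `CC(C)(C)c1ccc(C(=O)N2CCC3(CC2)C(=O)N(CC(=O)NCCCNS(C)(=O)=O)CN3c2ccccc2)cc1` has not yet been measured. It differs from compound 3 by (3-(methanesulfonamido)propyl)amino in place of 2-(hydroxymethyl)piperidin-1-yl on a carbonyl carbon. Among the compounds with values here, no measured step makes this exact exchange, so the nearest guide is compound 1, which also carries an open chain on the carbonyl carbon. Compound 1 gives 13700 nM, within the scatter of compound 3, and on that basis the step of a 1.0-fold higher number from compound 3 to compound 4 (0.01 log units; within the scatter) is expected to stay within the scatter, with no clear direction. Compound 4 is therefore expected to give about 12000 nM in this assay, most likely between 5000 nM and 30000 nM.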

Compound 4, half-maximal inhibitory concentration: 10400 nM
For compound 4 the middle estimate is 1.2-fold (0.06 log units) above the measured one; the measured number falls inside the stated range.
By their numbers in this assay, from the lowest: compound 2; then compounds 4, 3 and 1 (each within the scatter of the next).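

In this assay, the step of a 1.1-fold lower number from compound 3 to compound 4 (0.05 log units; within the scatter) shows that at this carbonyl carbon the open (3-(methanesulfonamido)propyl)amino chain, which has no ring, reads the same as the ring of 2-(hydroxymethyl)piperidin-1-yl. Yet the ring is not interchangeable with the chain in every form: the step of a 2.2-fold higher number from compound 2 to compound 4 (0.34 log units; beyond the scatter) places 4-hydroxypiperidin-1-yl clearly apart from the open chain, so compound 2 goes against any rule that all these groups behave alike. The step of a 1.3-fold lower number from compound 1 to compound 4 (0.12 log units; within the scatter) adds that methanesulfonamido in place of 2-((tert-butoxycarbonyl)amino)ethyl on a saturated chain carbon, three bonds along the chain from an amide-type nitrogen, also stays within the scatter, so the two open chains with different ends cannot be told apart on this read-out.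

Nothing available explains why compound 2 stands apart from the other three. Still open, as far as these compounds go, is whether a simple amine or a carboxylic acid at the end of the chain, a longer chain, or a hydroxyl group on an open chain would separate from compound 4 or come closer to compound 2.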